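The source may report more compounds than this note shows. Statements on the series, on what has been measured and on what is new or still open speak of the compounds shown alone.

Measured so far in a functional assay on the whole organism for inhibition, with Brassica napus as the target, with a stated time of 72 h, tested at 100 mg/L; a higher number here means more inhibition of growth at the concentration tested, a lower number less inhibition of growth:
compound 1, `COc1cc(C)nc2n/c(=N/C(=O)c3c(-c4ccc(Cl)cc4Cl)noc3C)sn12`, gives 80.6%
compound 2, `COc1cc(OC)n2s/c(=N\C(=O)c3c(-c4ccc(Cl)cc4Cl)noc3C)nc2n1`, gives 85.6%
compound 3, `COc1cc(OC)nc(NC(=S)NC(=O)c2c(-c3ccc(Cl)cc3Cl)noc2C)n1`, gives 70.8%

Compounds 1 and 2 share one core; compound 3 carries another, and the difference between the two cores is not broken down here. Compound 3 stands lowest of the three, with compound 1 within the scatter of it and compound 2 beyond it. Within the shared core, compound 1 differs from compound 2 by methyl in place of methoxy on an aromatic carbon, which gave a number 5 percentage points lower from compound 2 to compound 1 (within the scatter).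

Compound 4, `COc1cc(C)nc(NC(=S)NC(=O)c2c(-c3ccc(Cl)cc3Cl)noc2C)n1`, is not yet measured. It differs from compound 3 by methyl in place of methoxy on an aromatic carbon. The surroundings are not identical: in compound 2 the ring is part of a fused or bridged system of two rings, meta to a fused ring and para to a fused ring, whereas in compound 3 it is meta to a large group. The change is therefore the same kind of change, not the same.

The step of a number 3.8 percentage points lower from compound 3 to compound 4 (within the scatter) is expected to be small because a number 5 percentage points lower from compound 2 to compound 1 (within the scatter) was within the scatter. Compound 4 is estimated at 67%, expected between 55% and 78%.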

Compound 4, percent growth inhibition at one concentration: 69.3%
For compound 4 the middle estimate is 2.3 percentage points below the measured one; low and high end bracket the measured number.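

In this assay, methyl in place of methoxy gives a number 1.5 percentage points lower from compound 3 to compound 4 (within the scatter), and the step reads alike on the two cores: the same change on two cores in this assay, a number 5 percentage points lower (within the scatter) from compound 2 to compound 1 and a number 1.5 percentage points lower (within the scatter) from compound 3 to compound 4, 3.5 percentage points apart, within the scatter of two such steps

On the compounds shown, this change can be carried between the two cores without a step beyond the scatter. Among the compounds shown here, with only two pairs, both within the scatter, this does not show that the step has a fixed size, nor that it would hold on a third core or at another concentration.

Only methoxy and methyl appear at this place, one read-out at one concentration. The compounds shown leave open how an amine or a longer chain such as butoxy would read there on either core.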